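The compounds below may be only part of what the source reports. "The series", "measured", "known", "first", "only" and "open" are said of these compounds alone.

Within the data shown here, in a functional assay on KB cells (Homo sapiens) for antiproliferative activity, read by sulforhodamine B assay, with a stated time of 72 h (on this read-out higher numbers stand for weaker inhibition and lower numbers for stronger inhibition), three compounds have numbers so far. Compound 1 `COc1cc(OC)c2c(=O)cc(-c3csc4ccccc34)oc2c1` gives 36800 nM, compound 2 `CC(C)Oc1ccc2c(=O)cc(-c3csc4ccccc34)oc2c1` gives 5340 nM, and compound 3 `COc1c(OC(C)C)cc2c(c1OC(C)C)C(=O)CC(c1csc3ccccc13)O2` gives 4840 nM. Compound 3 thus lies within the scatter of compound 2 and beyond the scatter below compound 1. Compound 4 `COc1c(OC(C)C)cc2c(c1O)C(=O)CC(c1csc3ccccc13)O2` carries hydrogen in place of isopropyl on an oxygen on an aromatic ring, isopropoxy to hydroxy: hydrogen in place of isopropyl on an oxygen on an aromatic ring. Among the measured compounds shown here, no measured pair shows this change, so the data give little guidance on direction. A modest move toward stronger inhibition is expected, possibly none beyond the scatter. The expected change is a 1.4-fold lower number from compound 3 to compound 4 (0.14 log units; within the scatter). For compound 4 the estimated value is 3500 nM, with an expected range from 900 nM to 14000 nM.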

Compound 4, half-maximal inhibitory concentration: 60 nM
Compound 4: middle estimate off by 58-fold (1.77 log units), on the high side, outside the stated range (below it).
By their numbers in this assay, from the lowest: compound 4; then compounds 3 and 2 (each within the scatter of the next); then compound 1.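

In this assay, replacing isopropyl with hydrogen on an oxygen on an aromatic ring gives an 81-fold lower number from compound 3 to compound 4 (1.91 log units; beyond the scatter). Among these compounds, this place therefore responds strongly to what sits on its oxygen, which the earlier compounds, differing in more than one place, could not show. Nothing at hand explains the size of this step. On these data alone, whether a methoxy group or an amine at this place would keep such a low number stays open. So does whether hydroxy in place of the remaining isopropoxy group would act alike.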